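The source may report more compounds than this note shows. Statements on the series, on what has been measured and on what is new or still open speak of the compounds shown alone.

Compound 1 `Cc1ccc2[nH]c(C(=O)N[C@H]3CN(S(=O)(=O)C4CCOCC4)C[C@@H]3C(=O)NCCN(C)C)cc2c1` gives 90%; compound 2 `Cc1ccc2[nH]c(C(=O)N[C@H]3CCN(S(=O)(=O)C4CC4)C[C@@H]3C(=O)NCCN(C)C)cc2c1` gives 95%; compound 3 `O=C(N[C@H]1CN(S(=O)(=O)c2ccccc2)C[C@@H]1C(=O)NC[C@@H]1CCCN1)c1cc(-c2ccccc2Cl)on1` gives 102%.

In a functional assay on HEK293 cells for agonist activity at growth hormone secretagogue receptor type 1 (Homo sapiens), read by HTRF and inositol phosphate accumulation, with a stated time of 90 min, in the presence of a further agent that is not named here (a lower number here means a smaller maximal response, a higher number a larger maximal response), compound 3 gives the highest of the three numbers. Compound 2 stands close to it, within the usual scatter, while compound 1 stands further below it, beyond the scatter. Compound 4 `CC(=O)N1CCC[C@H](NC(=O)[C@H]2CN(S(=O)(=O)c3ccccc3)C[C@@H]2NC(=O)c2cc(-c3ccccc3Cl)on2)C1` keeps the core of compound 3 and differs in one place: 1-acetylpiperidin-3-yl in place of (pyrrolidin-2-yl)methyl on an amide-type nitrogen. Among the compounds with values here, no pair of measured compounds shows this kind of exchange, so no measured step speaks for its size; all three measured maximal responses lie near the reference, and no step beyond the scatter in either direction is expected. Compound 4 is therefore expected to give about 95%, within the range 80% to 110%. The expected step of a number 7 percentage points lower from compound 3 to compound 4 (within the scatter) is estimated to lie within the scatter.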

Compound 4, largest response reached (Emax), in percent of the reference or control that the assay uses: 91%
Beside the measured number, compound 4's estimate is 4 percentage points above it; measured number inside the range.
By their numbers in this assay, from the lowest: compounds 1, 4, 2 and 3 (each within the scatter of the next, the first and the last beyond it).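

In this assay, within the data shown here, putting 1-acetylpiperidin-3-yl in place of (pyrrolidin-2-yl)methyl on this amide-type nitrogen gives a number 11 percentage points lower from compound 3 to compound 4 (beyond the scatter), the first measured step at this position. The maximal response stays high, although the entering group has 0 hydrogen-bond donors where the leaving group has 1. No measurement available here accounts for the step. Going by these compounds, it remains open whether piperidin-3-yl without the acetyl, a primary amine on a longer chain or a carboxylic acid at this position would keep the response.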